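A few compounds are considered here, and "the series" means these few. Any claim that something is new, unique, unknown or untested is made for them only; others in the source may bear on it.

Compound 3 `Nc1nc(-c2cccc3ccccc23)cn1/N=C/c1cc2ccccc2nc1Cl` gives the lowest of the two numbers obtained in a functional assay on HCT-116 cells (Homo sapiens) for cytotoxicity, read by MTT assay, with a stated time of 48 h (a higher number here means a weaker inhibitor, a lower number a stronger inhibitor), namely 6340 nM. Its nearest neighbour is compound 2 `Cc1ccc2nc(Cl)c(/C=N/n3cc(-c4ccc(Br)cc4)nc3N)cc2c1`, which in this assay gives 49900 nM, a gap that lies beyond the scatter. Compound 1 `COc1ccc(-c2cn(/N=C/c3cc4cc(C)ccc4nc3Cl)c(N)n2)cc1` reaches only a limit in this assay, > 50000 nM. For the measured compounds named here, the one measured step, from compound 1 to compound 2, is a number no higher from compound 1 to compound 2 (the limit leaves the size open), and because of the limit of > 50000 nM in this assay, at which 1 of the 3 values shown sits, its size stays open.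

Compound 4 `Cc1ccc2nc(Cl)c(/C=N/n3cc(-c4cccc5ccccc45)nc3N)cc2c1` differs from compound 3 by methyl in place of hydrogen on an aromatic carbon. Going by the values given here, no measured step isolates this change: compounds 1, 2 and 4 all carry the methyl on the fused ring, and the step from compound 1 to compound 2 concerns the other end of the molecule. With nothing to point in either direction, the step from compound 3 to compound 4 in this assay is expected to be a 1.0-fold higher number from compound 3 to compound 4 (0.01 log units; within the scatter), no larger than the scatter. Compound 4 is therefore estimated at 6500 nM in this assay, within 2000 nM to 20000 nM.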

Compound 4, half-maximal inhibitory concentration: 5840 nM
Beside the measured number, compound 4's estimate is 1.1-fold (0.05 log units) above it; the range from low to high includes it.
By their numbers in this assay, from the lowest: compounds 4 and 3 (each within the scatter of the next); then compound 2. At a limit, above all of these: compound 1.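

Methyl in place of hydrogen on an aromatic carbon gives a 1.1-fold lower number from compound 3 to compound 4 (0.04 log units; within the scatter) in this assay, so with naphthalen-1-yl present this carbon of the fused system tolerates the methyl without a change beyond the scatter. For the compounds shown here, with that methyl present in both compounds, naphthalen-1-yl in place of 4-bromophenyl gives an 8.5-fold lower number from compound 2 to compound 4 (0.93 log units; beyond the scatter), the first step of readable size at the other end of the molecule. Naphthalen-1-yl in place of 4-methoxyphenyl gives an at least 8.5-fold lower number from compound 1 to compound 4 (0.93 log units; beyond the scatter), and its true size stays open because of a limit: the limit of > 50000 nM in this assay, at which 1 of the 4 values shown sits.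

The compounds shown leave open whether methyl would behave the same way alongside 4-bromophenyl or 4-methoxyphenyl. They also leave open how an ethyl group or an amine on the same aromatic carbon would compare.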